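Nitro for hydrogen, carried onto a second core

This account rests on a few compounds, and the source may have more. Where it says the series, first, only, none or still open, it means among the compounds named here.

Compound 1 `COc1ccc(-c2sccc2-c2cc(OC)c(OC)c(OC)c2)cc1` gives 4590 nM in a functional assay on HT-1080 cells (Homo sapiens) for antiproliferative activity, read by MTT assay, with a stated time of 72 h; on this read-out higher numbers stand for weaker inhibition and lower numbers for stronger inhibition. Compound 2 `COc1ccc(-c2sccc2-c2cc(OC)c(OC)c(OC)c2)cc1[N+](=O)[O-]`, which carries nitro in place of hydrogen on an aromatic carbon, gives 2100 nM in this assay; the step of a 2.2-fold lower number from compound 1 to compound 2 (0.34 log units; beyond the scatter). Compound 3 `CCOC(=O)c1cc(-c2ccc(OC)cc2)c(-c2cc(OC)c(OC)c(OC)c2)s1` gives 7630 nM in this assay, the highest number of the three; its gap to compound 1 lies within the scatter, its gap to compound 2 beyond it. How the core of compound 3 differs from the core of compound 1 is not broken down here.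

Compound 4 `CCOC(=O)c1cc(-c2ccc(OC)c([N+](=O)[O-])c2)c(-c2cc(OC)c(OC)c(OC)c2)s1` is not yet measured. Against compound 3 it carries nitro in place of hydrogen on an aromatic carbon. The place reads the same, word for word, as for the change from compound 1 to compound 2, so this is the same change, occurring twice among these compounds, once measured. The expectation rests on that single measured step, a 2.2-fold lower number from compound 1 to compound 2 (0.34 log units; beyond the scatter), carried over onto the core of compound 3. Compound 4 is therefore expected at 3500 nM in this assay, within a range from 1700 nM to 7000 nM. The expected step of a 2.2-fold lower number from compound 3 to compound 4 (0.34 log units; beyond the scatter) mirrors the earlier one, the range widened since one occurrence on a different core gives little hold.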

Compound 4, half-maximal inhibitory concentration: 26100 nM
For compound 4 the middle estimate is 7.5-fold (0.87 log units) below the measured one; the measured number lies above the stated range.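

The second occurrence of hydrogen to nitro, here 4-methoxyphenyl to 4-methoxy-3-nitrophenyl, gives a 3.4-fold higher number from compound 3 to compound 4 (0.53 log units; beyond the scatter) in this assay, so the direction of the change is not kept from one core to the other. The two occurrences disagree: the same change on two cores in this assay, a 2.2-fold lower number (0.34 log units; beyond the scatter) from compound 1 to compound 2 and a 3.4-fold higher number (0.53 log units; beyond the scatter) from compound 3 to compound 4, 7.5-fold (0.87 log units) apart, beyond the scatter of two such steps
In this series, then, a step read on the core of compound 1 cannot be assumed on the core of compound 3, but with a single step per core, neither direction can be called typical of the change, and nothing here shows which difference between the cores goes with the reversal.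

Open, on these data alone, is whether the opposite steps go with the ethyl ester shared by compound 3 and compound 4, which a carboxylic acid or an amide in its place could help to separate. Also open, as far as these compounds go, is whether an amine in place of the nitro group would follow the same split between the two cores.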